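This account rests on a few compounds, and the source may have more. Where it says the series, first, only, none or still open, it means among the compounds named here.

Working notes on the series. Compound 1 `Cc1cc(C)cc(NC(=O)COc2cc(C)nc3ccc(OC(F)(F)F)cc23)c1` gives 6.79 in a physicochemical assay for lipophilicity, read by HPLC, in phosphate buffer, measured as chromatographic lipophilicity, at pH 7.4 (a lower number here means a more polar compound, a higher number a more lipophilic compound), and compound 2 `COc1ccc2nc(C)cc(NC(=O)C(=O)Nc3cc(C)cc(C)c3)c2c1` gives 6.47. Compound 3 `COc1cccc(NC(=O)COc2cc(C)nc3ccc(OC)cc23)c1` gives 4.49 and stands lowest of the three numbers; compound 2 sits nearest, beyond the scatter above it, and compound 1 furthest, also beyond the scatter. The move to compound 4 `COc1ccc2nc(C)cc(OCC(=O)Nc3nc(C)c(C)s3)c2c1` exchanges one group on the amide-type nitrogen whose other neighbour is the carbonyl carbon: 4,5-dimethyl-1,3-thiazol-2-yl in place of 3-methoxyphenyl on an amide-type nitrogen. No comparable single change between measured compounds exists in this assay, so the expectation rests only on the groups exchanged. The expected step is small, a number 0.19 log units lower from compound 3 to compound 4 (within the scatter), probably not beyond the scatter, if anything downward. Compound 4 is therefore estimated at 4.3, within 3.6 to 5.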

Compound 4, distribution coefficient: 4.24
Compound 4: middle estimate off by 0.06 log units, on the high side; low and high end bracket the measured number.
By their numbers in this assay, from the lowest: compounds 4 and 3 (each within the scatter of the next); then compound 2; then compound 1.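

In this assay, for the compounds shown here, the exchange on the amide-type nitrogen gives the only one-place comparison, a number 0.25 log units lower from compound 3 to compound 4 (within the scatter), so at this place 4,5-dimethyl-1,3-thiazol-2-yl and 3-methoxyphenyl cannot be told apart in this read-out. A five-membered aromatic ring with 2 hetero atoms thus stands in for a six-membered aromatic ring of carbon only without a step beyond the scatter. No measured evidence bears on this result. Going by these compounds, whether an amine, a carboxylic acid or a longer alkyl chain on this nitrogen would read the same stays open, as does whether this exchange reads the same on the core of compound 1.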